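Changing the Amide Side Chain of a Weak Antiproliferative

This account rests on a few compounds, and the source may have more. Where it says the series, first, only, none or still open, it means among the compounds named here.

Compound 1 `CCN(CC)CCCNC(=O)c1ccc(C(CC)(CC)c2ccc(C#CC(O)(CC)CC)c(C)c2)n1CC` gives 8500 nM in a functional assay on PC-3 cells (Homo sapiens) for antiproliferative activity, read by MTT assay, with a stated time of 72 h; on this read-out higher numbers stand for weaker inhibition and lower numbers for stronger inhibition. Compound 2 `CCn1cc(C(CC)(CC)c2ccc(C#CC(O)(CC)CC)c(C)c2)cc1C(=O)NCC(=O)OC` gives 17500 nM in this assay, the higher of the two numbers, and its gap to compound 1 lies beyond the usual scatter. Compound 3 `CCn1cc(C(CC)(CC)c2ccc(C#CC(O)(CC)CC)c(C)c2)cc1C(=O)N[C@@H](C)CO` differs from compound 2 in one place: 1-(hydroxymethyl)ethyl in place of (methoxycarbonyl)methyl on an amide-type nitrogen. Going by the values given here, no measured pair shows this change, so its effect is unknown. The step is expected to stay within the scatter, with no clear direction: a 1.2-fold lower number from compound 2 to compound 3 (0.07 log units; within the scatter). Compound 3 is therefore estimated at 15000 nM, with a range from 6000 nM to 40000 nM.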

Compound 3, half-maximal inhibitory concentration: 6050 nM
Beside the measured number, compound 3's estimate is 2.5-fold (0.39 log units) above it; low and high end bracket the measured number.
By their numbers in this assay, from the lowest: compounds 3 and 1 (each within the scatter of the next); then compound 2.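

The side chain on this amide-type nitrogen affects activity in this assay: placing 1-(hydroxymethyl)ethyl in place of (methoxycarbonyl)methyl gives a 2.9-fold lower number from compound 2 to compound 3 (0.46 log units; beyond the scatter), a modest step. Going by these compounds alone, the earlier compounds formed no pair differing in one place, so this is the first direct reading of a change at this position. Nothing measured here explains the step.

As far as these compounds go, the hydroxyl group and the defined stereocentre enter together as the ester leaves, so their separate contributions remain open. How a carboxylic acid or a longer hydroxyalkyl chain would behave on this nitrogen is also unknown.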